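The source may report more compounds than this note shows. Statements on the series, on what has been measured and on what is new or still open speak of the compounds shown alone.

Measured compounds in a functional assay on GTL 16 cells for antiproliferative activity against GTL 16 cell line (Homo sapiens), read by CCK-8 assay, with a stated time of 72 h; on this read-out lower numbers stand for stronger inhibition and higher numbers for weaker inhibition:
compound 1, `O=C(Nc1cccc(-c2oc3cc(-c4ccc(F)cc4)ccc3c(=O)c2O)c1)c1ccc(F)cc1`: 14600 nM
compound 2, `COc1ccc(C(=O)Nc2cccc(-c3oc4cc(-c5ccc(F)cc5)ccc4c(=O)c3O)c2)cc1`: 21100 nM
compound 3, `Cc1ccccc1C(=O)Nc1cccc(-c2oc3cc(-c4ccc(F)cc4)ccc3c(=O)c2O)c1`: 24800 nM

Compound 2 stands second highest of the three numbers shown, but its gaps to compound 3 (nearest) and compound 1 (furthest) both lie within the scatter, so the three compounds are not separable on this read-out. Compound 4, `Cc1cccc(C(=O)Nc2cccc(-c3oc4cc(-c5ccc(F)cc5)ccc4c(=O)c3O)c2)c1`, is not yet measured; it is reached from compound 2 by 3-methylphenyl in place of 4-methoxyphenyl on a carbonyl carbon. For the measured compounds named here, three measured steps bear on the same position on the carbonyl carbon: a 1.4-fold higher number from compound 1 to compound 2 (0.16 log units; within the scatter), a 1.7-fold higher number from compound 1 to compound 3 (0.23 log units; within the scatter) and a 1.2-fold higher number from compound 2 to compound 3 (0.07 log units; within the scatter). All of them fall within the scatter, so exchanging one aryl group for another on this carbonyl carbon has so far produced no movement beyond the scatter. No step beyond the scatter is therefore expected in this assay from compound 2 to compound 4. The expected step is a 1.1-fold higher number from compound 2 to compound 4 (0.04 log units; within the scatter). Compound 4 is estimated at 23000 nM, with a range from 11000 nM to 48000 nM.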

Compound 4, half-maximal inhibitory concentration: 10900 nM
Estimate against measurement, compound 4: 2.1-fold (0.32 log units) above; the whole stated range lies above it.
By their numbers in this assay, from the lowest: compounds 4, 1, 2 and 3 (each within the scatter of the next, the first and the last beyond it).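

In this assay the aryl group on this carbonyl carbon gives its first step beyond the scatter, a 2.3-fold lower number from compound 3 to compound 4 (0.36 log units; beyond the scatter) for 3-methylphenyl in place of 2-methylphenyl, so the placing of the methyl on the phenyl ring can register here, though only modestly. The steps of a 1.9-fold lower number from compound 2 to compound 4 (0.29 log units; within the scatter) and a 1.3-fold lower number from compound 1 to compound 4 (0.13 log units; within the scatter) stay within the scatter, so compound 4 is not separated from compound 2 or compound 1 and 3-methylphenyl stands out only against 2-methylphenyl. Nothing available accounts for the gap between these two methylphenyl groups.

Whether 4-methylphenyl or 3-methoxyphenyl would follow compound 4 remains open, since every group shown on this carbonyl carbon is a substituted phenyl. Also open, on these data alone, is how an aminomethyl group or a carboxylic acid on that phenyl would behave, with the shared core held constant throughout.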